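Nucleoside series: vinyl in place of propyl on the sugar

The source may report more compounds than this note shows. Statements on the series, on what has been measured and on what is new or still open speak of the compounds shown alone.

Three nucleosides have been run in a functional assay on KB cells (Homo sapiens), read by MTT assay; a lower number here means a stronger inhibitor, a higher number a weaker inhibitor. Compound 1 `C#C[C@@H]1[C@@H](O)[C@H](n2ccc(=O)[nH]c2=O)O[C@@H]1CO` gives only a limit there, > 350000 nM. Compound 3 `C#C[C@]1(O)[C@H](O)[C@@H](CO)O[C@H]1n1ccc(N)nc1=O` likewise gives only a limit, > 350000 nM. Compound 2 `CCC[C@@]1(O)[C@@H](CO)O[C@@H](n2ccc(=O)[nH]c2=O)[C@@H]1O` stands at the same limit, > 350000 nM, so no number is known for it, and every value shown is a limit (the limit of > 350000 nM in this assay, at which 3 of the 3 values shown sit). For the measured compounds named here, no step between measured compounds is available. Compound 4 `C=C[C@@]1(O)[C@@H](CO)O[C@@H](n2ccc(=O)[nH]c2=O)[C@@H]1O` differs from compound 2 in one place: vinyl in place of propyl on a saturated ring carbon. With all measured compounds at the limit, no step beyond the scatter is expected in this assay, and the expected step is a step that the limit leaves unreadable from compound 2 to compound 4. Compound 4 is expected at 400000 nM in this assay, with a range from 100000 nM to 2000000 nM, most probably again reported only as a limit.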

Compound 4, half-maximal inhibitory concentration: 51800 nM
Compound 4: middle estimate off by 7.7-fold (0.89 log units), on the high side; the measured number lies below the stated range.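

In this assay, vinyl in place of propyl on this saturated ring carbon gives an at least 6.7-fold lower number from compound 2 to compound 4 (0.82 log units; beyond the scatter). The position therefore responds to a change of group, and compound 4 is the only compound shown with a number rather than a limit. The step has only a lower bound because its starting value is a limit: the limit of > 350000 nM in this assay, at which 3 of the 4 values shown sit.

Whether the double bond or the shorter chain accounts for the step remains open. An ethyl group at this position would separate the two.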